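From a Phenylpiperazine to a Carbamoyl Triazole

A few compounds are considered here, and "the series" means these few. Any claim that something is new, unique, unknown or untested is made for them only; others in the source may bear on it.

Compound 1, `NS(=O)(=O)c1cc(-c2nnc(CN3CCN(c4ccccc4)CC3)o2)c(Cl)cc1SCc1ccccc1`, gives 0.33 h in an ADME assay on microsomes from liver (Homo sapiens) for metabolic stability, read by LC-MS, using NADPH, tested at 5 uM; a higher number here means that the compound lasts longer, a lower number that the compound disappears faster.
Compound 2, `Cc1ccc(C)c(N2CCN(Cc3nnc(-c4cc(S(N)(=O)=O)c(SCc5ccccc5)cc4Cl)o3)CC2)c1`, gives 0.208 h in this assay.

For the measured compounds named here, compound 1 stands highest of the two numbers in this assay, with compound 2 nearest; the one measured step, a 1.6-fold lower number from compound 1 to compound 2 (0.20 log units; within the scatter), lies within the scatter, so the two compounds cannot be told apart. Compound 3, `NC(=O)c1cn(Cc2nnc(-c3cc(S(N)(=O)=O)c(SCc4ccccc4)cc3Cl)o2)nn1`, has not yet been measured. It differs from compound 1 in one place: 4-carbamoyl-1H-1,2,3-triazol-1-yl in place of 4-phenylpiperazin-1-yl on a saturated chain carbon bound to an aromatic carbon. Going by the values given here, the only measured step concerns the phenyl on an amine nitrogen in a ring and does not touch the group exchanged here, so it gives no guide to the change from compound 1 to compound 3. Among the compounds with values here, with no bearing step, the expected step of a 1.4-fold higher number from compound 1 to compound 3 (0.13 log units; within the scatter) is kept small and of uncertain direction. Compound 3 is therefore estimated to give about 0.45 h in this assay, within a range from 0.2 h to 1 h.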

Compound 3, half-life: 0.435 h
For compound 3 the middle estimate is 1.0-fold (0.01 log units) above the measured one; low and high end bracket the measured number.
By their numbers in this assay, from the lowest: compounds 2, 1 and 3 (each within the scatter of the next, the first and the last beyond it).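

Compound 3 shows that the whole 4-phenylpiperazin-1-yl, not only the phenyl on its amine nitrogen, can be exchanged on the saturated chain carbon bound to an aromatic carbon: in this assay the step is a 1.3-fold higher number from compound 1 to compound 3 (0.12 log units; within the scatter), so compound 1 and compound 3 cannot be told apart. The entering 4-carbamoyl-1H-1,2,3-triazol-1-yl has fewer heavy atoms, a single five-membered aromatic ring in place of two six-membered rings, and a hydrogen-bond donor where the group it replaces has none, yet this large difference in structure gives no readable difference in half-life. What lies behind this result cannot be said from the data at hand.

As far as these compounds go, it remains open whether a carboxylic acid in place of the carbamoyl, or a morpholine in place of the triazole, would give a number beyond the scatter. From the compounds shown here alone, it also remains open whether any exchange elsewhere on the shared core would do so.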